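The compounds below may be only part of what the source reports. "The series", "measured", "known", "first", "only" and "open" are said of these compounds alone.

Of the compounds shown here, two have been measured in an assay on HEK293 cells for displacement of a labelled ligand from corticotropin-releasing factor receptor 1 (Homo sapiens), read by scintillation proximity assay, with a stated time of 2 h (a higher number here means a weaker inhibitor, a lower number a stronger inhibitor), so far. Compound 1 `CCCN(CCC)c1cccc2nc(Nc3c(C)cc(C)cc3C)c(=O)n(C)c12` gives 672 nM in this assay. Compound 2 `CCCN(CCC)c1cccc2nc(Nc3c(OC)cc(COC)cc3OC)c(C)cc12` gives 472 nM in this assay, and the gap between these two numbers lies within the usual scatter of the method, so the two compounds stand on equal footing; compound 2 and compound 1 also differ in several places at once, so no single change can be read from them.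

Compound 3 `CCCN(CCC)c1cccc2nc(Nc3c(OC)cc(OC)cc3OC)c(C)cc12` is not yet measured. It differs from compound 2 in one place: methoxy in place of methoxymethyl on an aromatic carbon. Going by the values given here, no measured pair shows what such an exchange does here, and the change is small in size, so the expected step from compound 2 to compound 3 in this assay is a 1.1-fold higher number from compound 2 to compound 3 (0.03 log units; within the scatter), a shift no larger than the scatter in either direction. Compound 3 is therefore estimated at 500 nM in this assay, with a range from 200 nM to 1300 nM.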

Compound 3, half-maximal inhibitory concentration: > 1000 nM
Compound 3: a limit, no number (the forecaster's own chance of this, stated with the estimate: 3%); middle value at least 2.0-fold (0.30 log units) away from the limit.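

The place where compound 2 and compound 3 differ turns out to matter, something compound 1 and compound 2 could not show because they differ in several places at once. In this assay compound 3 gives > 1000 nM, which is a limit of the assay and not a number. Putting methoxy in place of methoxymethyl on this aromatic carbon, para to a large group, gives an at least 2.1-fold higher number from compound 2 to compound 3 (0.32 log units; beyond the scatter), so even this small exchange weakens the compound here.

On these data alone, only these two groups are compared at this place, so it stays open whether a longer chain such as ethoxymethyl, or an amine such as aminomethyl, would give a lower number than methoxymethyl or a higher one. As far as these compounds go, the full size of the step also stays open: the limit of > 1000 nM in this assay, at which 1 of the 3 values shown sits.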